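The compounds below may be only part of what the source reports. "The series", "measured", "known", "first", "only" and "open" are said of these compounds alone.

Compound 1 `O=C(/C(=C\c1ccccc1OCc1ccccc1)S(=O)(=O)Cc1ccc(F)cc1)c1ccc(Cl)cc1` was tested in a functional assay on DU-145 cells (Homo sapiens) for inhibition, read by trypan blue exclusion, with a stated time of 96 h (on this read-out higher numbers stand for weaker inhibition of growth and lower numbers for stronger inhibition of growth), where compound 1 gives 10000 nM. Compound 2 `Cc1ccc(CS/C(=C/c2ccc(O)cc2)C(=O)c2ccc(Cl)cc2)cc1` is a related compound; in this assay compound 2 gives 10000 nM, so the two stand level within the scatter. Compound 3 `COc1ccc(S(=O)(=O)/C(=C/c2ccccc2OCc2ccccc2)C(=O)c2ccc(Cl)cc2)cc1` has not yet been measured. Its structure differs from compound 1 in one place: 4-methoxyphenyl in place of 4-fluorobenzyl on a sulfonyl sulfur. Within the data shown here, no measured pair shows the effect of this change, so the expectation rests only on where compound 1 stands at 10000 nM. The estimated step is no change at the digits printed from compound 1 to compound 3 (within the scatter), none beyond the scatter. Compound 3 is therefore expected to give about 10000 nM, between 4000 nM and 25000 nM.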

Compound 3, concentration for 50% growth inhibition: 1000 nM
Compound 3: middle estimate off by 10-fold (1.00 log units), on the high side; the measured number lies below the stated range.
By their numbers in this assay, from the lowest: compound 3; then compounds 1 and 2 (each within the scatter of the next).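

In this assay, this sulfonyl position responds to its substituent: 4-methoxyphenyl in place of 4-fluorobenzyl gives a 10-fold lower number from compound 1 to compound 3 (1.00 log units; beyond the scatter), so the position is not indifferent to what it carries. The earlier compounds shown here held no pair that could show this. No measurement shown gives a reason for the step.

From the compounds shown here alone, the change swaps benzyl for phenyl and fluorine for methoxy together, and these two parts cannot be separated here. 4-Fluorophenyl or 4-methoxybenzyl on the same sulfonyl sulfur would tell them apart, and how an amine-bearing ring would fare remains open.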